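This account rests on a few compounds, and the source may have more. Where it says the series, first, only, none or still open, it means among the compounds named here.

Working notes on the series. Compound 1, `C[Se]c1nc(N)c2ccccc2n1`, is measured in a functional assay on HT-29 cells (Homo sapiens) for cytotoxicity, read by MTT assay, with a stated time of 72 h; a higher number here means a weaker inhibitor of growth, a lower number a stronger inhibitor of growth; in that test compound 1 gives 27600 nM. Compound 2, `CSc1nc(NCCCc2ccccc2)c2ccccc2n1`, is the second measured member; in this assay compound 2 gives 19600 nM. The two numbers lie within the usual scatter of each other, so the data give no separation between compound 1 and compound 2 on this test, and nothing can be said of which is the stronger inhibitor of growth.

Compound 3, `CSc1nc(NCCCCc2ccccc2)c2ccccc2n1`, is not yet measured. It differs from compound 2 by benzyl in place of phenyl on a saturated chain carbon, three bonds along the chain from a nitrogen on an aromatic ring. For the measured compounds named here, no measured pair shows a step of this kind, so there is no measured step to lean on. Going by the values given here, with only two measured compounds, which do not separate from each other, the expectation is no step beyond the scatter. The estimated step from compound 2 to compound 3 is a 1.1-fold lower number from compound 2 to compound 3 (0.04 log units; within the scatter). For compound 3 in this assay the estimate is 18000 nM, expected to fall between 7000 nM and 45000 nM.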

Compound 3, concentration for 50% growth inhibition: > 100000 nM
Compound 3: a limit, no number (the forecaster's own chance of this, stated with the estimate: 10%); middle value at least 5.5-fold (0.74 log units) from the limit.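

The series now has its first step beyond the scatter: in this assay, benzyl in place of phenyl on a saturated chain carbon, three bonds along the chain from a nitrogen on an aromatic ring, gives an at least 5.1-fold higher number from compound 2 to compound 3 (0.70 log units; beyond the scatter). The position is therefore not indifferent to this change, although the two groups share one six-membered aromatic ring of carbon only, carry no hydrogen-bond donors or acceptors, and differ only as 6 heavy atoms against 7, with compound 3 the weaker inhibitor of growth of this pair. In this assay compound 3 gives > 100000 nM, which is a limit and not a number, so the step can be read only as a bound on its size: the limit of > 100000 nM in this assay, at which 1 of the 3 values shown sits.

As far as these compounds go, how far compound 3 really lies from compound 2 remains unknown. Also open, from the compounds shown here alone, is whether a longer chain at this position stays at the limit, and whether an amine or a carboxylic acid in place of the phenyl or benzyl at the chain end brings growth inhibition back into the measurable range.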